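A few compounds are considered here, and "the series" means these few. Any claim that something is new, unique, unknown or untested is made for them only; others in the source may bear on it.

Measured compounds in this study:

- compound 1 `Cc1cc(CN2CCN(c3c(Br)cnc4[nH]c(-c5ccc(CN)cc5)nc34)CC2)no1` — > 50%
- compound 2 `Cc1cc(CN2CCN(c3c(Cl)cnc4[nH]c(-c5ccc(CN)cc5)nc34)CC2)no1` — > 50%
- compound 3 `Cc1cc(CN2CCN(c3c(Cl)cnc4[nH]c(N5CCN(C)CC5)nc34)CC2)no1` — > 50%

In an ADME assay on microsomes from liver (Mus musculus, strain CD1) for metabolic stability, read by LC-MS, with a stated time of 30 min, tested at 10 uM (a lower number here means that less of the compound is left, a higher number that more of the compound is left), compound 1 gives > 50%, which is a limit of the assay and not a number. Compound 2 likewise gives > 50%, a limit. Compound 3 gives > 50%, again a limit. Every value shown therefore sits at the limit of > 50% in this assay, at which 3 of the 3 values shown sit, and both steps between measured neighbours, a step that the two limits leave unreadable from compound 1 to compound 2 and a step that the two limits leave unreadable from compound 2 to compound 3, cannot be read in size or direction.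

The next compound is compound 4 `Cc1cc(CN2CCN(c3c(Br)cnc4[nH]c(-c5ccc(CN(C)C)cc5)nc34)CC2)no1`. The change from compound 1 is dimethylamino in place of amino on a saturated chain carbon bound to an aromatic carbon. Neither measured step touches this position: the steps from compound 1 to compound 2 and from compound 2 to compound 3 concern the halogen on the core and the group replacing 4-(aminomethyl)phenyl, not the aminomethyl chain itself. Going by the values given here, nothing measured in this assay therefore bears directly on the change, and the only guide is that all three compounds share the core and all sit at the limit.

The expectation for compound 4 is accordingly a step that the limit leaves unreadable from compound 1 to compound 4 of no readable size beyond the scatter, most likely again a limit. The estimated value for compound 4 is 62%, in a range from 40% to 88%.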

Compound 4, percent of the compound remaining: > 50%
Compound 4 ended at the assay's limit; the forecaster's own chance of this, stated with the estimate: 65%; the middle value is on the limit's open side.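

Compound 4 gives > 50% in this assay, which is a limit of the assay and not a number. Compound 1 also stands at a limit, so no step from compound 1 to compound 4 can be read in size or direction: the limit of > 50% in this assay, at which 4 of the 4 values shown sit.

The compounds shown leave open how much of each actually remains, and whether amino and dimethylamino differ at all.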